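Chloro added to an aryl ring: expected effect on L6 cytotoxicity

The source may report more compounds than this note shows. Statements on the series, on what has been measured and on what is new or still open speak of the compounds shown alone.

Measured so far:
compound 1 `O=[N+]([O-])c1ccc(-n2ccc(C(c3ccccc3)n3ccnc3)c2)cc1` gives 60400 nM
compound 2 `O=[N+]([O-])c1ccc(-n2ccc(C(c3ccc(Cl)cc3)n3ccnc3)c2)cc1` gives 82400 nM
compound 3 `Clc1ccc(-n2ccc(C(c3ccc(Cl)cc3Cl)n3ccnc3)c2)cc1` gives 13900 nM

In an ADME assay on L6 cells (Rattus norvegicus) for cytotoxicity, read by fluorescence and resazurin assay, with a stated time of 72 h (on this read-out higher numbers stand for lower toxicity in this test and lower numbers for higher toxicity in this test), compound 1 and compound 2 differ only by chloro in place of hydrogen on an aromatic carbon, and the step is a 1.4-fold higher number from compound 1 to compound 2 (0.13 log units; within the scatter). Compound 3 has a different core; the difference between the two cores is not broken down here. Compound 4 `Clc1ccc(C(c2ccn(-c3ccc(Cl)cc3Cl)c2)n2ccnc2)c(Cl)c1` differs from compound 3 by chloro in place of hydrogen on an aromatic carbon. This is the same kind of change as that between compound 1 and compound 2, but the place is not identical: in compound 2 the chloro sits para to a large group, whereas in compound 4 it sits ortho to a large group and meta to a chloro group. Because the earlier step of a 1.4-fold higher number from compound 1 to compound 2 (0.13 log units; within the scatter) was small, the step of a 1.2-fold higher number from compound 3 to compound 4 (0.06 log units; within the scatter) is expected to be small as well, though the different placement leaves room for surprise. Compound 4 is therefore estimated at 16000 nM, with a range from 6000 nM to 45000 nM, and this assay will show where it truly stands.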

Compound 4, half-maximal cytotoxic concentration: 9260 nM
Compound 4: the middle estimate sits 1.7-fold (0.24 log units) above what was measured; measured number inside the range.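

Chloro in place of hydrogen on an aromatic carbon gives a 1.5-fold lower number from compound 3 to compound 4 (0.18 log units; within the scatter) in this assay on the core of compound 3, and the same change on the core of compound 1 gives a step that does not differ from it: the same change on two cores in this assay, a 1.4-fold higher number (0.13 log units; within the scatter) from compound 1 to compound 2 and a 1.5-fold lower number (0.18 log units; within the scatter) from compound 3 to compound 4, 2.0-fold (0.31 log units) apart, within the scatter of two such steps

In both pairs, then, the change leaves the number within the usual scatter, whichever of the two cores carries it. This does not show that the chloro is without effect on every core in the series, for only two pairs are shown and the chloro sits in a different place in each.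

The compounds shown leave open whether another group on the same aromatic carbon, such as an amine, a methoxy group or a carboxylic acid, would also leave the number within the scatter.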